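This account rests on a few compounds, and the source may have more. Where it says the series, first, only, none or still open, it means among the compounds named here.

The study asks how strongly a small series of compounds built on one shared core kills a human colon cancer cell line, measured in an ADME assay on HCT-116 cells (Homo sapiens) for cytotoxicity, read by CellTiter-Glo, with a stated time of 72 h; a lower number here means a stronger inhibitor, a higher number a weaker inhibitor. Among the compounds with values here, compound 1 `CC1CCN(C2CCN(S(=O)(=O)c3cccnc3)CC2)CC1` is the first member. In this assay compound 1 reaches only the assay limit, > 10000 nM, which is a boundary of the measurement and not a number, as shown by the limit of > 10000 nM in this assay, at which 1 of the 2 values shown sits. Compound 2 `CC1CCN(C2CCN(S(=O)(=O)c3ccc(-c4ccccc4)cc3)CC2)CC1` carries a phenyl at the end of the core. In this assay compound 2 likewise gives a limit rather than a number, > 5000 nM, as shown by the limit of > 5000 nM in this assay, at which 1 of the 2 values shown sits. So compound 2 stands where every value so far stands: at a limit, with no measurable number beneath it.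

Compound 3 `COC(=O)c1ccc(S(=O)(=O)N2CCC(N3CCC(C)CC3)CC2)cc1` differs from compound 2 by methoxycarbonyl in place of phenyl on an aromatic carbon. Within the data shown here, no measured step between two compounds is available to guide the size of this change. The step that the limit leaves unreadable from compound 2 to compound 3 is expected to stay within the usual scatter, with no clear direction. Compound 3 is therefore estimated at 15000 nM, ranging from 5000 nM to 50000 nM, and most likely reported again as a limit.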

Compound 3, half-maximal inhibitory concentration: > 5000 nM
Compound 3 ended at the assay's limit (the forecaster's own chance of this, stated with the estimate: 70%); the middle value lies beyond the limit too.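

No size can be read for the change from compound 2 to compound 3, because both compounds end at a limit of the assay and neither gives a number: the limit of > 5000 nM in this assay, at which 2 of the 3 values shown sit.

The compounds shown leave open how strongly any of them kills these cells in this assay, and whether methoxycarbonyl in place of phenyl changes that strength at all.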